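A new side group on a shared core

The source may report more compounds than this note shows. Statements on the series, on what has been measured and on what is new or still open speak of the compounds shown alone.

In a functional assay on A549 cells (Homo sapiens) for cytotoxicity, read by MTT assay, with a stated time of 72 h (a higher number here means a weaker inhibitor, a lower number a stronger inhibitor), compound 1 `CN(C)CCCCCn1c2c(c3ccccc31)C(=O)c1c[n+]([O-])c3ccccc3c1C2=O` gives 210 nM and compound 2 `O=C1c2c[n+]([O-])c3ccccc3c2C(=O)c2c1c1ccccc1n2Cc1cn([C@@H]2C[C@H](O)[C@@H](CO)O2)nn1` gives 120 nM on the same core. Compound 3 `O=C1c2c[n+]([O-])c3ccccc3c2C(=O)c2c1c1ccccc1n2CCCCN1CCCCC1` gives 150 nM and sits among them, within the scatter of both. Compound 4 `O=C1c2c[n+]([O-])c3ccccc3c2C(=O)c2c1c1ccccc1n2Cc1cn(C[C@@H](O)CO)nn1` has not yet been measured. In it, 1-(2,3-dihydroxypropyl)-1H-1,2,3-triazol-4-yl takes the place of 3-(piperidin-1-yl)propyl on a saturated chain carbon bound to an aromatic nitrogen 1-(2,3-dihydroxypropyl)-1H-1,2,3-triazol-4-yl in place of 3-(piperidin-1-yl)propyl on a saturated chain carbon bound to an aromatic nitrogen and that is a large swap. For the measured compounds named here, the only measured step at a single place is a 1.4-fold lower number from compound 1 to compound 3 (0.15 log units; within the scatter) and it put piperidin-1-yl in place of (dimethylamino)methyl, a much smaller swap. Compound 2, with 120 nM as its value, also has a five-membered aromatic ring in its side group. On this thin evidence, no step beyond the scatter is expected in this assay and the expected step is a 1.1-fold lower number from compound 3 to compound 4 (0.03 log units; within the scatter) here. The estimated value for compound 4 is 140 nM with an expected range from 50 nM to 400 nM around that estimate.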

Compound 4, half-maximal inhibitory concentration: 390 nM
For compound 4 the middle estimate is 2.8-fold (0.44 log units) below the measured one; the measured number falls inside the stated range.
By their numbers in this assay, from the lowest: compounds 2, 3, 1 and 4 (each within the scatter of the next, the first and the last beyond it).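

Replacing the 3-(piperidin-1-yl)propyl group with 1-(2,3-dihydroxypropyl)-1H-1,2,3-triazol-4-yl gives a step in this assay that lies beyond the scatter (a 2.6-fold higher number from compound 3 to compound 4 (0.41 log units; beyond the scatter)), so a change at this position can shift the number measurably. Compound 2 and compound 4 share the five-membered aromatic ring, yet 2,3-dihydroxypropyl in place of 4-hydroxy-5-(hydroxymethyl)oxolan-2-yl on its aromatic nitrogen also gives a step beyond the scatter (a 3.3-fold higher number from compound 2 to compound 4 (0.51 log units; beyond the scatter)), so that ring alone does not fix the number and its substituent counts too. The same side group replacing 4-(dimethylamino)butyl shows no clear change (a 1.9-fold higher number from compound 1 to compound 4 (0.27 log units; within the scatter)), so the size of the effect depends on the compound used for comparison.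

No measurement here explains why these numbers differ. Going by these compounds, it remains open whether a carboxylic acid or a morpholine ring on that aromatic nitrogen would give a number nearer that of compound 2 or that of compound 4.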